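Changing the phenyl group of compound 3

The source may report more compounds than this note shows. Statements on the series, on what has been measured and on what is new or still open speak of the compounds shown alone.

In an ADME assay (liver) for metabolic stability, with Liver microsome (Homo sapiens) as the target, read by LC-MS, using microsomes, with a stated time of 30 min, tested at 4 uM (a higher number here means that more of the compound is left, a lower number that less of the compound is left), compound 3 `Cc1nc(N2CCN(C)CC2)c2nc(-c3cccc(Cl)c3)n(C3CCOCC3)c2n1` gives 25%. Compound 2 `Cc1nc(N2CCN(C)CC2)c2nc(-c3ccccc3Cl)n(C3CC3)c2n1` gives 31%. The gap between compound 2 and compound 3 lies within the scatter. Compound 1 `Cc1nc(N2CCN(C)CC2)c2nc(-c3ccccc3Cl)n(CCN3CCCC3=O)c2n1` gives 13%. The gap between compound 1 and compound 3 lies beyond the scatter, with compound 3 the higher of the two. Compound 4 `Cc1nc(N2CCN(C)CC2)c2nc(-c3ccccc3C(F)(F)F)n(C3CCOCC3)c2n1` keeps the oxan-4-yl group of compound 3 and replaces 3-chlorophenyl with 2-(trifluoromethyl)phenyl on an aromatic carbon: 2-(trifluoromethyl)phenyl in place of 3-chlorophenyl on an aromatic carbon. For the measured compounds named here, the only measured step, a number 18 percentage points higher from compound 1 to compound 2 (beyond the scatter), is modest and changes the group on an aromatic nitrogen, so it bears on this change only loosely. Going by the values given here, no measured step changes the phenyl group, so no shift beyond the scatter is expected. The estimated step is a number 2 percentage points lower from compound 3 to compound 4 (within the scatter). Compound 4 is expected at 23%, within an estimated range of 10% to 38%.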

Compound 4, percent of the compound remaining: 24%
Compound 4: the middle estimate sits 1 percentage points below what was measured, and the stated range covers the measured number.
By their numbers in this assay, from the lowest: compound 1; then compounds 4, 3 and 2 (each within the scatter of the next).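

On the aromatic carbon of the five-membered aromatic ring, with the oxan-4-yl group held fixed, this assay gives a number 1 percentage points lower from compound 3 to compound 4 (within the scatter). This is the only step shown that exchanges the phenyl group, and here 2-(trifluoromethyl)phenyl and 3-chlorophenyl cannot be told apart, whereas the earlier step concerned only the group on an aromatic nitrogen. Nothing at hand bears on the reason for this result.

Still open, from the compounds shown here alone, is whether a nitrile or a methoxy group on the phenyl ring, or a pyridyl group in its place, would move the number beyond the scatter.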